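A few compounds are considered here, and "the series" means these few. Any claim that something is new, unique, unknown or untested is made for them only; others in the source may bear on it.

Working notes on the amide side chain of the shared core.

Compound 3 `COCCNC(=O)c1[nH]cc(C(=O)OC2CC3CCC2C3)c1C` is the reference point; in an assay on CHO cells for inhibition of metabotropic glutamate receptor 1 (Homo sapiens) (on this read-out higher numbers stand for weaker inhibition and lower numbers for stronger inhibition), compound 3 gives 158 nM. Compound 1 `CC(=O)NCCCCNC(=O)c1[nH]cc(C(=O)OC2CC3CCC2C3)c1C` carries the longer side chain, the change being (2-acetamidoethyl in place of methoxy on a saturated chain carbon, two bonds along the chain from an amide-type nitrogen). In this assay compound 1 gives 200 nM, so the step of a 1.3-fold higher number from compound 3 to compound 1 (0.10 log units; within the scatter) is small and not distinguishable from repeat measurement.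

Compound 2 `COCCNC(=O)c1[nH]c(C)c(C(=O)OC2CC3CCC2C3)c1C` has a different core: the difference from compound 3 is methyl in place of hydrogen on an aromatic carbon. In this assay compound 2 gives 316 nM; the step of a 2.0-fold lower number from compound 2 to compound 3 (0.30 log units; within the scatter) is again within the scatter, and compound 2 holds the highest of the three numbers without standing apart from either neighbour.

Compound 4 `CC(=O)NCCCCNC(=O)c1[nH]c(C)c(C(=O)OC2CC3CCC2C3)c1C` is not yet measured. Relative to compound 2 it carries 2-acetamidoethyl in place of methoxy on a saturated chain carbon, two bonds along the chain from an amide-type nitrogen, which is the same change as that from compound 3 to compound 1, made on the same place and applied to the core of compound 2 rather than that of compound 3. The expected step of a 1.3-fold higher number from compound 2 to compound 4 (0.10 log units; within the scatter) in this assay is set beside the measured 1.3-fold higher number from compound 3 to compound 1 (0.10 log units; within the scatter) and is expected to be of similar size, because a 1.3-fold higher number from compound 3 to compound 1 (0.10 log units; within the scatter) showed the chain extension to be close to neutral on the other core. Compound 4 is therefore estimated at 400 nM, with an expected range from 200 nM to 800 nM.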

Compound 4, half-maximal inhibitory concentration: 1000 nM
The estimate for compound 4 lay 2.5-fold (0.40 log units) below the measured number; the measured number lies above the stated range.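

In this assay, replacing methoxy with 2-acetamidoethyl on the core of compound 2 gives a 3.2-fold higher number from compound 2 to compound 4 (0.50 log units; beyond the scatter), and this step cannot be separated from the same change on the core of compound 3: the same change on two cores in this assay, a 1.3-fold higher number (0.10 log units; within the scatter) from compound 3 to compound 1 and a 3.2-fold higher number (0.50 log units; beyond the scatter) from compound 2 to compound 4, 2.5-fold (0.40 log units) apart, within the scatter of two such steps

Read from the other side, methyl in place of hydrogen on an aromatic carbon gives a 5.0-fold higher number from compound 1 to compound 4 (0.70 log units; beyond the scatter) with the 4-acetamidobutyl amide in place, and this step likewise cannot be separated from the step with the 2-methoxyethyl amide: the same change on two cores in this assay, a 2.0-fold lower number (0.30 log units; within the scatter) from compound 2 to compound 3 and a 5.0-fold lower number (0.70 log units; beyond the scatter) from compound 4 to compound 1, 2.5-fold (0.40 log units) apart, within the scatter of two such steps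

These comparisons show no difference beyond the scatter in how either change behaves from one core to the other, so carrying a change across these cores remains compatible with the data, but they neither prove that the changes add up nor rule out a dependence on the core, since each comparison rests on a single pair of steps.

Still open, on these data alone, is whether the same holds for other side-chain endings, such as a primary amine or a carboxylic acid, or for a longer chain than 4-acetamidobutyl. Also open, as far as these compounds go, is whether an ethyl group on that aromatic carbon would behave as methyl does with each side chain.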